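Replacing Trifluoromethyl by Methyl on the Phenyl Ring

This account rests on a few compounds, and the source may have more. Where it says the series, first, only, none or still open, it means among the compounds named here.

Compound 1, `Fc1ccc(C2CC(c3ccc(Cl)s3)=NN2c2nc(-c3ccc(C(F)(F)F)cc3)cs2)cc1`, gives a limit of > 500 ug/mL in a functional assay on A549 cells (Homo sapiens) for antiproliferative activity, read by XTT assay, with a stated time of 24 h; a lower number here means a stronger inhibitor, a higher number a weaker inhibitor.
Compound 2, `Cc1ccc(C2=NN(c3nc(-c4ccc(C(F)(F)F)cc4)cs3)C(c3ccc(F)cc3)C2)s1`, gives a limit of > 500 ug/mL in this assay.
Compound 3, `COc1ccc(-c2csc(N3N=C(c4ccc(C)s4)CC3c3ccc(F)cc3)n2)cc1`, gives 184 ug/mL in this assay.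

Compound 1 stands at a limit of this assay: its value is not a number, so its place among the three compounds cannot be fixed. The same limit holds for most of the values shown (the limit of > 500 ug/mL in this assay, at which 2 of the 3 values shown sit). Compound 4, `Cc1ccc(-c2csc(N3N=C(c4ccc(Cl)s4)CC3c3ccc(F)cc3)n2)cc1`, differs from compound 1 in one place: methyl in place of trifluoromethyl on an aromatic carbon. Going by the values given here, of the measured steps, the one from compound 2 to compound 3 also removes the trifluoromethyl from that ring, putting methoxy there, and it gave an at least 2.7-fold lower number from compound 2 to compound 3 (0.43 log units; beyond the scatter). The step that the two limits leave unreadable from compound 1 to compound 2 swapped chloro for methyl elsewhere in the molecule and says nothing about this position. Compound 1 is itself only a limit, so the change in compound 4 may bring the number below that limit, as methoxy did in compound 3, or leave it unreadable. Compound 4 is therefore expected to give around 300 ug/mL, between 120 ug/mL and 700 ug/mL, which corresponds to an estimated step of an at least 1.6-fold lower number from compound 1 to compound 4 (0.22 log units; that floor lies within the scatter).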

Compound 4, half-maximal inhibitory concentration: > 500 ug/mL
Compound 4: a limit, no number; the forecaster's own chance of this, stated with the estimate: 45%; middle value at least 1.6-fold (0.22 log units) from the limit.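

Compound 4, like compound 1, gives a limit and not a number, so no step between the two can be read: the limit of > 500 ug/mL in this assay, at which 3 of the 4 values shown sit.

The compounds shown leave open whether methyl in place of trifluoromethyl on the phenyl ring changes the number in this assay at all, in either direction.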